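Removing One Chloro from the Dichlorophenyl Styryl Sulfone

This account rests on a few compounds, and the source may have more. Where it says the series, first, only, none or still open, it means among the compounds named here.

Compound 1, `O=S(=O)(/C=C/c1ccc(F)cc1)Cc1ccc(Nc2ncnc3ccccc23)cc1`: 1000 nM
Compound 2, `N#Cc1ccc(/C=C/S(=O)(=O)Cc2ccc(Nc3ncnc4ccccc34)cc2)cc1`: a limit of the assay, > 100000 nM
Compound 3, `O=S(=O)(/C=C/c1ccc(Cl)c(Cl)c1)Cc1ccc(Nc2ncnc3ccccc23)cc1`: 35000 nM

Three compounds share one core and differ only in the aryl group on the double-bonded chain. Within the data shown here, in a functional assay on PC-3 cells (Homo sapiens) (on this read-out higher numbers stand for weaker inhibition of growth and lower numbers for stronger inhibition of growth), compound 3 gives 35000 nM, the higher of the two real numbers; the only other number is that of compound 1, and the step is a 35-fold higher number from compound 1 to compound 3 (1.54 log units; beyond the scatter). Compound 2 reports only a limit, (the limit of > 100000 nM in this assay, at which 1 of the 3 values shown sits), so compound 3 stands below it by an at least 2.8-fold lower number from compound 2 to compound 3 (0.45 log units; beyond the scatter).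

Compound 4, `O=S(=O)(/C=C/c1ccc(Cl)cc1)Cc1ccc(Nc2ncnc3ccccc23)cc1`, differs from compound 3 by hydrogen in place of chloro on an aromatic carbon. Among the measured compounds shown here, no measured step removes a single chloro; the nearest evidence is a 35-fold higher number from compound 1 to compound 3 (1.54 log units; beyond the scatter), which moves from a single para-halogen to the 3,4-dichlorophenyl, and an at least 2.8-fold lower number from compound 2 to compound 3 (0.45 log units; beyond the scatter). Compound 4 keeps one para-halogen, as compound 1 does, so a number between compound 3 and compound 1 is expected. Compound 4 is expected to give 5000 nM, within 1500 nM to 20000 nM. This is expected to be a 7.0-fold lower number from compound 3 to compound 4 (0.85 log units; beyond the scatter).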

Compound 4, concentration for 50% growth inhibition: 43000 nM
For compound 4 the middle estimate is 8.6-fold (0.93 log units) below the measured one; measured number above the stated range.
By their numbers in this assay, from the lowest: compound 1; then compounds 3 and 4 (each within the scatter of the next). At a limit, above all of these: compound 2.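

In this assay, taking away the chloro ortho to the other chloro leaves the read-out unresolved, a 1.2-fold higher number from compound 3 to compound 4 (0.09 log units; within the scatter), so the 3,4-dichlorophenyl and the 4-chlorophenyl cannot be told apart here. Among these compounds, the large gap to compound 1 therefore does not depend on a second chloro, since the single exchange of fluoro for chloro on the aromatic carbon still gives a 43-fold higher number from compound 1 to compound 4 (1.63 log units; beyond the scatter). Exchanging the cyano for chloro gives an at least 2.3-fold lower number from compound 2 to compound 4 (0.36 log units; beyond the scatter), a step that starts from a limit of the assay: the limit of > 100000 nM in this assay, at which 1 of the 4 values shown sits.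

Among the groups shown, only the fluoro of compound 1 stands apart from the others. As far as these compounds go, how a plain phenyl would read remains open, as does whether a methoxy or an amine on that carbon would come close to compound 1 or stay with compound 3 and compound 4.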